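The source may report more compounds than this note shows. Statements on the series, on what has been measured and on what is new or still open speak of the compounds shown alone.

Measured so far:
- compound 1 `C[C@@H](CC(=O)O)CC(=O)c1c([C@@H](O)CCCCCc2ccccc2)n(C)c2ccc(Cl)cc12`: 120 nM
- compound 2 `C[C@H](CC(=O)O)CC(=O)c1c([C@@H](O)CCCCCc2ccccc2)n(C)c2ccc(Cl)cc12`: 0.38 nM
- compound 3 `CC(CC(=O)O)CC(=O)n1c(CCCc2ccccc2)cc2ccc(Cl)cc21`: 210 nM

In a functional assay for antagonist activity at Oxoeicosanoid receptor 1 (Homo sapiens), read by fluorescence and calcium flux, with stated times of 2 min and 1 min (a higher number here means a weaker inhibitor, a lower number a stronger inhibitor), compound 1 gives 120 nM and stands second highest of the three numbers; compound 3 sits nearest, within the scatter of it, while compound 2 lies far below. Going by the values given here, the only single-point step in the set is the one from compound 1 to compound 2, where the configuration at the saturated chain carbon is inverted and the number falls a 320-fold lower number from compound 1 to compound 2 (2.50 log units; beyond the scatter); that this step is a matter of configuration alone is the fact of the fact that compounds 1 and 2 differ only in the configuration as drawn.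

Compound 4 `C[C@@H](CC(=O)O)CC(=O)c1c(CCCCCCc2ccccc2)n(C)c2ccc(Cl)cc12` keeps the configuration of compound 1 and changes (hydrogen in place of hydroxy on a saturated chain carbon bound to an aromatic carbon and a saturated chain carbon), that is, hydrogen in place of hydroxy on a saturated chain carbon bound to an aromatic carbon and a saturated chain carbon. Among the compounds with values here, no measured step in this assay touches that change: the step from compound 1 to compound 2 concerns configuration only, and compound 3 differs from compound 1 in several places at once. A step of any particular size or direction cannot therefore be read off; the expectation is a step of a 1.7-fold higher number from compound 1 to compound 4 (0.22 log units; within the scatter), held within the scatter but with a wide range. Compound 4 is expected to give 200 nM in this assay, between 50 nM and 1500 nM.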

Compound 4, half-maximal inhibitory concentration: 23 nM
For compound 4 the middle estimate is 8.7-fold (0.94 log units) above the measured one; the whole stated range lies above it.
By their numbers in this assay, from the lowest: compound 2; then compound 4; then compounds 1 and 3 (each within the scatter of the next).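

Hydroxy on the saturated chain carbon bound to an aromatic carbon and a saturated chain carbon is not required for activity with the configuration of compound 1: in this assay, hydrogen in its place gives a 5.2-fold lower number from compound 1 to compound 4 (0.72 log units; beyond the scatter) and the series keeps its activity. Going by these compounds alone, the earlier single-point step concerned configuration only, so this is the first reading of a change in the atoms at this place, and it runs towards a lower number. Nothing at hand gives a reason for this step.

From the compounds shown here alone, the step is read on one configuration only, so whether hydrogen in place of hydroxy moves the number the same way with the configuration of compound 2 stays open. Also open, going by these compounds, is how a methoxy group, a fluorine atom or an amine on this carbon would compare with hydroxy and hydrogen.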